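Replacing the sulfur-linked ring at the carbonyl of compound 3

The compounds below may be only part of what the source reports. "The series", "measured", "known", "first", "only" and "open" are said of these compounds alone.

Compound 1 `Cc1nc(S(C)(=O)=O)ccc1Oc1ncnc(OC2CCN(C(=O)SC(C)C)CC2)c1F`, compound 2 `Cc1nc(S(C)(=O)=O)ccc1Oc1ncnc(OC2CCN(C(=O)SC3CC3)CC2)c1F` and compound 3 `Cc1nc(S(C)(=O)=O)ccc1Oc1ncnc(OC2CCN(C(=O)SC3(C)CC3)CC2)c1F` share one core and differ only in the group attached through sulfur to the carbonyl carbon. In a functional assay on isolated protein for inhibition of Glucose-dependent insulinotropic receptor (Rattus norvegicus), read by HTRF and cAMP accumulation (a lower number here means that less compound is needed, a higher number that more compound is needed for the effect), compound 1 gives 41.3 nM, compound 2 gives 126 nM and compound 3 gives 166 nM. Compound 3 thus stands at the highest of the three numbers, though its gap to compound 2 is within the scatter a 1.3-fold higher number from compound 2 to compound 3 (0.12 log units; within the scatter), while its gap to compound 1 is beyond it a 4.0-fold higher number from compound 1 to compound 3 (0.60 log units; beyond the scatter); the step of a 3.1-fold higher number from compound 1 to compound 2 (0.48 log units; beyond the scatter) shows the same direction.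

Compound 4 `CCC(F)(F)C(=O)N1CCC(Oc2ncnc(Oc3ccc(S(C)(=O)=O)nc3C)c2F)CC1` changes compound 3 at that same carbonyl carbon: a group of 5 heavy atoms (3 carbon, 2 fluorine; no ring) in place of a group of 5 heavy atoms (4 carbon, 1 sulfur; one three-membered non-aromatic ring of carbon only), on a carbonyl carbon. Among the compounds with values here, no measured step removes the sulfur or introduces fluorine, so the three steps bear only indirectly, showing that changes at this position have moved the number only modestly, as the steps of a 3.1-fold higher number from compound 1 to compound 2 (0.48 log units; beyond the scatter) and a 4.0-fold higher number from compound 1 to compound 3 (0.60 log units; beyond the scatter) show. The direction of the new change cannot be read from them. Compound 4 is therefore expected to fall near 90 nM, with a range from 25 nM to 350 nM. The expected step is a 1.8-fold lower number from compound 3 to compound 4 (0.27 log units; within the scatter), leaning toward a lower number but with wide uncertainty.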

Compound 4, half-maximal effective concentration: 69.2 nM
Compound 4: the middle estimate sits 1.3-fold (0.11 log units) above what was measured, and the stated range covers the measured number.
By their numbers in this assay, from the lowest: compounds 1, 4, 2 and 3 (each within the scatter of the next, the first and the last beyond it).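

Replacing the group attached through sulfur with 1,1-difluoropropyl shows that a sulfur link at this carbonyl carbon is not required for activity in this assay, with the change giving a 2.4-fold lower number from compound 3 to compound 4 (0.38 log units; beyond the scatter), a step beyond the scatter. The same replacement does not separate from the other two sulfur-linked groups, since a 1.8-fold lower number from compound 2 to compound 4 (0.26 log units; within the scatter) and a 1.7-fold higher number from compound 1 to compound 4 (0.22 log units; within the scatter) both lie within the scatter. The earlier steps shown here varied only the group on sulfur, whereas this one replaces the whole sulfur-linked group, and it also shows that a group with no ring can serve at this position in this assay.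

No measurement shown here gives a reason for these steps. The compounds shown leave open whether the fluorine atoms contribute to the number, which a plain propyl chain on the same carbonyl carbon would test, and whether an oxygen link in place of the sulfur would match the sulfur-linked compounds or compound 4.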